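Swapping the aryl group on sulfur in compound 3

The compounds below may be only part of what the source reports. "The series", "measured", "known", "first", "only" and "open" are said of these compounds alone.

- compound 1 `CC(C)(C)c1ccc(SC(=S)N2CCCCC2)cc1` gives 9130 nM
- compound 2 `CCCCN(CCCC)C(=S)Sc1ccccc1` gives 9760 nM
- compound 3 `COc1ccc(SC(=S)N2CCN(C(=O)OC(C)(C)C)CC2)cc1` gives 712 nM

These numbers come from a functional assay on A549 cells (Homo sapiens) for antiproliferative activity, read by MTT assay, with a stated time of 72 h; a higher number here means a weaker inhibitor, a lower number a stronger inhibitor. Compound 3 is the strongest of the three, and its gaps to compound 1 and compound 2 both lie beyond the scatter. The next compound, compound 4 `CC(C)(C)OC(=O)N1CCN(C(=S)Sc2ccccc2Cl)CC1`, keeps the rest of compound 3 and changes one group: 2-chlorophenyl in place of 4-methoxyphenyl on a sulfur. Among the measured compounds shown here, no two measured compounds differ in only one place, so the data give no direct size for this swap. For the measured compounds named here, with compound 3 at 712 nM as the lowest number so far, a rise seems more likely than a fall. Even so, the retained remainder suggests a number that stays lower than the one for compound 1, which gives 9130 nM. The expected shift is a 2.1-fold higher number from compound 3 to compound 4 (0.32 log units; beyond the scatter), a moderate weakening beyond the scatter, though the estimate is uncertain. The estimated value for compound 4 is 1500 nM, with an expected range from 450 nM to 5500 nM.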

Compound 4, half-maximal inhibitory concentration: 1560 nM
Beside the measured number, compound 4's estimate is 1.0-fold (0.02 log units) below it, within the range that was stated.
By their numbers in this assay, from the lowest: compound 3; then compound 4; then compounds 1 and 2 (each within the scatter of the next).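

Among the compounds shown here, compound 3 and compound 4 are the first pair here that differ in only one place, so the aryl group on the sulfur now has a measured effect in this assay. Replacing 4-methoxyphenyl with 2-chlorophenyl gives a 2.2-fold higher number from compound 3 to compound 4 (0.34 log units; beyond the scatter), a modest weakening, which shows that this position responds to the swap but that activity is not lost. No evidence on the cause of this rise is available.

From the compounds shown here alone, whether the rise comes from the change of substituent or from its place on the ring stays open, since 2-chlorophenyl and 4-methoxyphenyl differ in both. Also open, going by these compounds, is how an aryl group carrying an amine or a carboxylic acid would behave on this sulfur with the rest of compound 3 kept.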